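The source may hold more compounds than are shown below. What is called first, only, known or untested is meant among the compounds shown, and "the series" means these compounds.

Metabolic stability in an in vitro ADME assay on microsomes from liver (Homo sapiens) for metabolic stability, read by LC-MS, tested at 1 uM (a higher number here means that the compound lasts longer, a lower number that the compound disappears faster), is followed across three measured members of this series and one that remains to be run.

Compound 2 `CC(C)n1ccnc1/N=C(\N)Nc1ccc(Cl)c(Cl)c1` gives in this assay only a limit of the assay, > 1 h. Compound 1 `CC(C)N/C(=N\c1nccn1C(C)C)Nc1ccc(Cl)c(Cl)c1` gives 0.375 h in this assay. Compound 3 `N/C(=N\c1ncc[nH]1)Nc1ccc(Cl)c(Cl)c1` gives 0.708 h in this assay.

Compound 1 differs from compound 2 by isopropyl in place of hydrogen on an amine nitrogen. That change brings an at least 2.6-fold lower number from compound 2 to compound 1 (0.42 log units; beyond the scatter); the step is only known as a floor because of the limit of > 1 h in this assay, at which 1 of the 3 values shown sits.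

Compound 3 differs from compound 2 in the core: hydrogen in place of isopropyl on an aromatic nitrogen. Here the step is an at least 1.4-fold lower number from compound 2 to compound 3 (0.14 log units; that floor lies within the scatter), so the two cores cannot be told apart on this read-out.

Compound 4 `CC(C)N/C(=N\c1ncc[nH]1)Nc1ccc(Cl)c(Cl)c1` is not yet measured. Its difference from compound 3 is isopropyl in place of hydrogen on an amine nitrogen, the same change as that from compound 2 to compound 1, with the place described in identical terms. The expectation for compound 4 therefore rests on compound 2 and compound 1, where the change gave an at least 2.6-fold lower number from compound 2 to compound 1 (0.42 log units; beyond the scatter), applied to the value of compound 3, 0.708 h. For compound 4 the expected step is a 2.8-fold lower number from compound 3 to compound 4 (0.45 log units; beyond the scatter). Compound 4 is thus estimated at 0.25 h, with a likely range from 0.12 h to 0.55 h. With the starting point of compound 3 already a number and not a limit, a limit readout for compound 4 is not expected.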

Compound 4, half-life: > 1 h
Compound 4: a limit, no number; the forecaster's own chance of this, stated with the estimate: 3%; at least 4.0-fold (0.60 log units) between middle value and limit.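

In this assay compound 4 gives only a limit of the assay, > 1 h, so every step into it is known only as a floor, and the true sizes stay unknown: the limit of > 1 h in this assay, at which 2 of the 4 values shown sit.

Isopropyl in place of hydrogen on an amine nitrogen gives an at least 1.4-fold higher number from compound 3 to compound 4 (0.14 log units; that floor lies within the scatter), so the drop seen with the same change on the core of compound 2 does not carry over to the core of compound 3, and the two steps differ: the same change on two cores in this assay, an at least 2.6-fold lower number (0.42 log units; beyond the scatter) from compound 2 to compound 1 and an at least 1.4-fold higher number (0.14 log units; that floor lies within the scatter) from compound 3 to compound 4, at least 3.7-fold (0.57 log units) apart, beyond the scatter of two such steps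

Read the other way, hydrogen in place of isopropyl on an aromatic nitrogen gives an at least 2.6-fold higher number from compound 1 to compound 4 (0.42 log units; beyond the scatter), so the outcome of each change depends on the other place, though this rests on a single set of four compounds and shows nothing about how large the dependence is or whether it holds on any further core: the same change on two cores in this assay, an at least 1.4-fold lower number (0.14 log units; that floor lies within the scatter) from compound 2 to compound 3 and an at least 2.6-fold higher number (0.42 log units; beyond the scatter) from compound 1 to compound 4, at least 3.7-fold (0.57 log units) apart, beyond the scatter of two such steps

Still open, from the compounds shown here alone, is whether methyl, cyclopropyl or a longer chain on either nitrogen would show the same dependence on the core. Also open, going by these compounds, is how long compound 2 and compound 4 actually last in this assay, which would take a read-out extending past the limit.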